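The source may report more compounds than this note shows. Statements on the series, on what has been measured and on what is new or still open speak of the compounds shown alone.

In an assay on isolated protein for inhibition of high affinity 3',5'-cyclic-AMP phosphodiesterase 7A (Homo sapiens), read by scintillation proximity assay and cAMP accumulation, with a stated time of 20 min, tested at 10 uM (on this read-out lower numbers stand for less inhibition and higher numbers for more inhibition at the one concentration tested (going by the name of the read-out)), compound 2 `O=c1c2ccncc2[nH]c(=S)n1-c1ccccc1` gives 9.3%, the highest of the two numbers available, though the gap to compound 1 lies within the scatter. Compound 1 `COc1ccc(Cn2c(=O)[nH]c3ncccc3c2=O)cc1` gives 8% in this assay. Compound 3 `O=c1c2ccncc2[nH]c(=S)n1-c1cccnc1` has not yet been measured; it differs from compound 2 by pyridin-3-yl in place of phenyl on an aromatic nitrogen. For the measured compounds named here, no step between two measured compounds is known, so nothing here shows what such a change does. The step is expected to be a number 0.7 percentage points higher from compound 2 to compound 3 (within the scatter), no larger than the scatter in either direction. Compound 3 is therefore estimated at 10%, with a range from 0% to 25%.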

Compound 3, a percentage reported as inhibition, at one concentration (the size of the read-out at that concentration, not a potency): 2.7%
The estimate for compound 3 lay 7.3 percentage points above the measured number; the range from low to high includes it.
By their numbers in this assay, from the lowest: compounds 3, 1 and 2 (each within the scatter of the next).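

For the compounds shown here, this is the first step read at this position, the aromatic nitrogen of the shared core. Measured in this assay, pyridin-3-yl in place of phenyl amounts to a number 6.6 percentage points lower from compound 2 to compound 3 (within the scatter) and so cannot be told apart from no change at all. Nothing available explains this result. Left open is whether a longer chain on that nitrogen, or an amine or a carboxylic acid on its ring, would give a step beyond the scatter.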